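From compound 3 to compound 4: adding a phenyl

This account rests on a few compounds, and the source may have more. Where it says the series, first, only, none or still open, it means among the compounds named here.

Measured in a functional assay on MT2 cells (Homo sapiens) for antiproliferative activity, read by MTT assay, with a stated time of 72 h; a higher number here means a weaker inhibitor of growth, a lower number a stronger inhibitor of growth (three compounds):
- Compound 1 `O=C(COc1ccc2oc(-c3ccccc3)cc(=O)c2c1)Nc1ccc2ccccc2c1` gives > 10000 nM (a limit of the assay, not a number)
- Compound 2 `O=C(COc1ccc2c(=O)c(-c3ccccc3)coc2c1)Nc1ccc2ccccc2c1` gives 7680 nM
- Compound 3 `O=C(COc1c(-c2ccccc2)oc2ccccc2c1=O)Nc1ccccc1` gives 6720 nM

Going by the values given here, at 6720 nM compound 3 lies within the usual scatter of compound 2 (7680 nM), the only other true number in the set. The next structure, compound 4 `O=C(COc1c(-c2ccccc2)oc2ccccc2c1=O)Nc1ccc(-c2ccccc2)cc1`, departs from compound 3 by phenyl in place of hydrogen on an aromatic carbon (phenyl in place of hydrogen on an aromatic carbon, para to a large group). Among the compounds with values here, no measured pair isolates this change. In this assay no step beyond the scatter is expected, in either direction. The estimated move a 1.1-fold lower number from compound 3 to compound 4 (0.05 log units; within the scatter) is accordingly small. For compound 4 the expected value is 6000 nM (estimated range 2000 nM to 10000 nM).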

Compound 4, concentration for 50% growth inhibition: > 10000 nM
Compound 4: no number, only a limit (the forecaster's own chance of this, stated with the estimate: 30%); middle value at least 1.6-fold (0.22 log units) away from the limit.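

In this assay, phenyl in place of hydrogen on this aromatic carbon, para to a large group, gives an at least 1.4-fold higher number from compound 3 to compound 4 (0.17 log units; that floor lies within the scatter). Compound 4 gives > 10000 nM, which is a limit of the assay and not a number. The change therefore brings no measurable gain at this position, though the true size of the step stays unknown, and the reading ends at the assay's ceiling: the limit of > 10000 nM in this assay, at which 2 of the 4 values shown sit.

On these data alone, how far past that limit compound 4 lies remains open. So does whether an amine or a carboxylic acid on this carbon would give a true number.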